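The compounds below may be only part of what the source reports. "The series", "measured", "known", "first", "only" and "open" are said of these compounds alone.

Measured in a functional assay on KB 3-1 cells (Homo sapiens) for cytotoxicity, read by MTT assay, with a stated time of 68 h; on this read-out lower numbers stand for stronger inhibition and higher numbers for weaker inhibition:
Compound 1, `O=C(Nc1cccc(-c2ccccc2C(F)(F)F)c1)C(Cl)Cl`, gives 35900 nM.
Compound 2, `O=C(Nc1cccc(-c2ccc(-c3ccccc3)cc2)c1)C(Cl)Cl`, reaches only the limit > 50000 nM, which is a limit of the assay and not a number.
Compound 3, `COc1cccc(-c2cc(NC(=O)C(Cl)Cl)cc(-c3cccc(OC)c3)c2)c1`, reaches only the limit > 30000 nM, which is likewise a limit of the assay and not a number.

Within the data shown here, compound 1 thus holds the only number in this assay; the other two entries are limits, so no measured step between compounds exists within the set to lean on. Compound 4, `Cc1ccccc1-c1cccc(NC(=O)C(Cl)Cl)c1`, is the next entry and has not yet been measured in this assay. It differs from compound 1 in one place: methyl in place of trifluoromethyl on an aromatic carbon. Among the measured compounds shown here, nothing among the measured compounds isolates this change, and the two remaining entries give only limits. For the measured compounds named here, with no measured step of this kind, the expectation for compound 4 is a step within the usual scatter, a 1.0-fold lower number from compound 1 to compound 4 (0.01 log units; within the scatter), with no direction beyond it. Compound 4 is accordingly estimated at 35000 nM, with a range from 12000 nM to 100000 nM.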

Compound 4, half-maximal inhibitory concentration: 42000 nM
Compound 4: the middle estimate sits 1.2-fold (0.08 log units) below what was measured; low and high end bracket the measured number.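

In this assay, among these compounds, methyl in place of trifluoromethyl on an aromatic carbon, ortho to a large group, gives a 1.2-fold higher number from compound 1 to compound 4 (0.07 log units; within the scatter), the first step that can be read as a number. At this position, this read-out does not tell the two groups apart, even though one heavy atom replaces four. No measured property of either group accompanies this step.

Going by these compounds, whether an amine, a carboxylic acid or a longer chain on this same aromatic carbon would give a step beyond the scatter remains open. Equally open, on these data alone, is whether the exchange of methyl and trifluoromethyl stays within the scatter on another core.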